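The compounds below may be only part of what the source reports. "The series", "measured", "known", "first", "only" and "open" are said of these compounds alone.

The measured compounds are:
compound 1, `COc1ccc(NC(=S)NC(=O)c2cn(-c3ccccc3)nc2-c2ccc(OC)cc2)cc1`, 2570 nM;
compound 2, `O=C(NC(=S)Nc1ccc(Cl)cc1)c1cn(-c2ccccc2)nc1-c1ccc(Cl)cc1`, 3260 nM;
compound 3, `O=C(NC(=S)Nc1ccc(Cl)cc1)c1cn(-c2ccccc2)nc1-c1ccccc1`, 4020 nM.

All three were tested in a functional assay on NCI-H460 cells (Homo sapiens) for inhibition, read by CCK-8 assay, with a stated time of 48 h; on this read-out lower numbers stand for stronger inhibition and higher numbers for weaker inhibition. Compound 1 stands lowest of the three numbers, but its gaps to compound 2 and compound 3 are within the scatter, so no ranking among them can be claimed. Compound 4 is `COc1ccc(-c2nn(-c3ccccc3)cc2C(=O)NC(=S)Nc2ccc(C)cc2)cc1`. It differs from compound 1 in one place: methyl in place of methoxy on an aromatic carbon. Among the compounds with values here, no measured step changes this group; the only single-point step, a 1.2-fold higher number from compound 2 to compound 3 (0.09 log units; within the scatter), concerns hydrogen in place of chloro and lies within the scatter. There is thus no basis for expecting a shift beyond the scatter. Compound 4 is expected at 2800 nM, with a range of 1400 nM to 5600 nM. The expected step is therefore a 1.1-fold higher number from compound 1 to compound 4 (0.04 log units; within the scatter).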

Compound 4, half-maximal inhibitory concentration: 2880 nM
Beside the measured number, compound 4's estimate is 1.0-fold (0.01 log units) below it; low and high end bracket the measured number.
By their numbers in this assay, from the lowest: compounds 1, 4, 2 and 3 (each within the scatter of the next).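

In this assay, methyl in place of methoxy on the (4-methoxyphenyl)amino ring gives a 1.1-fold higher number from compound 1 to compound 4 (0.05 log units; within the scatter). Within the data shown here, this is the only single-place step at this position, as the earlier step concerned chloro on the other ring. Here, a hydrogen-bond acceptor is lost from this position with no difference beyond the scatter. Nothing available explains this result.

Going by these compounds, an amine, a carboxylic acid or a longer chain such as butoxy at this position remains open, so the tolerance seen here covers only methoxy and methyl.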